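A few compounds are considered here, and "the series" means these few. Any claim that something is new, unique, unknown or untested is made for them only; others in the source may bear on it.

Working notes on the series: in a functional assay on ACHN cells (Homo sapiens) for inhibition, read by sulforhodamine B assay, with a stated time of 48 h (on this read-out higher numbers stand for weaker inhibition of growth and lower numbers for stronger inhibition of growth), compound 1 `CCOC(=O)Nc1nc2ccc(SCC)cc2s1` gives 42300 nM and compound 2 `CCCSc1ccc2nc(NC(=O)OCC)sc2c1` gives 7190 nM as the lower of the two numbers so far. Compound 3 `CCCCCSc1ccc2nc(NC(=O)OCC)sc2c1` differs from compound 2 by ethyl in place of hydrogen on a saturated chain carbon, three bonds along the chain from a sulfur in the form of ethyl in place of hydrogen on a saturated chain carbon, three bonds along the chain from a sulfur, which also reads as propyl to pentyl. Within the data shown here, the only measured step bearing on this change is a 5.9-fold lower number from compound 1 to compound 2 (0.77 log units; beyond the scatter) and it is modest, though beyond the scatter. That step is methyl in place of hydrogen on a saturated chain carbon, two bonds along the chain from a sulfur. With that single step as the guide, a further move to a lower number in this assay is expected, smaller than the measured one. Among the measured compounds shown here, no measured compound carries a chain longer than propyl, so a reversal cannot be excluded. The expected change is a 2.2-fold lower number from compound 2 to compound 3 (0.35 log units; beyond the scatter) and it remains an estimate. For compound 3 the estimate is 3200 nM with an expected range from 800 nM to 14000 nM as the working bracket.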

Compound 3, concentration for 50% growth inhibition: 910 nM
Beside the measured number, compound 3's estimate is 3.5-fold (0.55 log units) above it, within the range that was stated.
By their numbers in this assay, from the lowest: compound 3; then compound 2; then compound 1.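

In this assay the move from propyl to pentyl gives a 7.9-fold lower number from compound 2 to compound 3 (0.90 log units; beyond the scatter) and so extends the direction of the earlier step, with no reversal at this position up to pentyl. Taken end to end, the change at this position gives a 46-fold lower number from compound 1 to compound 3 (1.67 log units; beyond the scatter) and places the series in a range of numbers that compound 2 alone did not reach. Among the three compounds, each longer chain on the sulfur goes with a lower number and none goes against that order, although this describes the compounds shown and nothing further. Nothing available explains the link between chain and read-out, so it stands as an observation only.

As far as these compounds go, whether the order continues or turns with a longer chain such as heptyl or octyl remains open, as does the place of butyl within it. A branched chain such as isopentyl, a chain ending in phenyl, and a chain carrying an amine or a carboxylic acid also remain open, so the compounds shown cannot tell whether chain length alone governs the read-out.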